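Chlorophenyl urea on the methoxy-bearing core

The source may report more compounds than this note shows. Statements on the series, on what has been measured and on what is new or still open speak of the compounds shown alone.

Two ureas built on a shared core have been examined in an assay on isolated protein for inhibition of serine/threonine-protein kinase PLK1 (Homo sapiens), read by radiometric assay and 33P incorporation, with a stated time of 40 min, tested at 20 uM, in the presence of a further agent that is not named here; on this read-out lower numbers stand for less inhibition and higher numbers for more inhibition at the one concentration tested (going by the name of the read-out). Compound 1, `CCNc1cc(-c2ccc(NC(=O)Nc3ccccc3Cl)cc2C)ccn1`, gives 49.2% in this assay. Compound 2, `CCNc1cc(-c2ccc(NC(=O)Nc3c(C)cccc3C)cc2OC)ccn1`, gives 54.4% in this assay. Compound 2 holds the higher of the two numbers, but the gap to compound 1 is within the usual scatter of such measurements, so the two values are not told apart.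

The unmeasured compound 3, `CCNc1cc(-c2ccc(NC(=O)Nc3ccccc3Cl)cc2OC)ccn1`, is drawn from compound 2 by one change on the urea: 2-chlorophenyl in place of 2,6-dimethylphenyl on an amide-type nitrogen. Within the data shown here, the group that enters is the one already carried by compound 1 on its own core. Among the measured compounds shown here, no measured pair in this set shows what this change alone does, so its size is open.

Since compound 1 and compound 2 sit together within the scatter in this assay, compound 3 is expected to sit near both, with no step beyond the scatter foreseen in either direction. The expected step from compound 2 to compound 3 is a number 4.4 percentage points lower from compound 2 to compound 3 (within the scatter). The estimate for compound 3 is 50%, with a range of 30% to 70%.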

Compound 3, a percentage reported as inhibition, at one concentration (the size of the read-out at that concentration, not a potency): 53.6%
Compound 3: the middle estimate sits 3.6 percentage points below what was measured; measured number inside the range.
By their numbers in this assay, from the lowest: compounds 1, 3 and 2 (each within the scatter of the next).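

In this assay, among these compounds, compound 3 gives the first pair that isolates the change on the urea: 2-chlorophenyl in place of 2,6-dimethylphenyl on an amide-type nitrogen gives a number 0.8 percentage points lower from compound 2 to compound 3 (within the scatter). At this position, on the methoxy-bearing core, the two groups are therefore not told apart at the one concentration tested. Compound 3 also opens a second single-change pair, methoxy in place of methyl on an aromatic carbon, which gives a number 4.4 percentage points higher from compound 1 to compound 3 (within the scatter), so neither place has yet produced a step beyond the scatter in this assay.

The compounds shown carry only these two substituted phenyl groups on the urea, so it remains open whether a quite different group there, such as a pyridine or a phenyl ring bearing a carboxylic acid, would shift the inhibition beyond the scatter. From the compounds shown here alone, it is equally open whether an amine or a longer ethoxy chain in place of the methoxy on the aromatic carbon would do so, and these single-concentration readings give no potency for any of the compounds. No accompanying information bears on either of these two results.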